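This account rests on a few compounds, and the source may have more. Where it says the series, first, only, none or still open, it means among the compounds named here.

Measured so far:
compound 1 `CCOC(=O)C1=C(N/N=C(/C#N)C(=O)OCC)Nc2[nH]nc(C)c2C1c1ccc(N(C)C)cc1` — 46400 nM
compound 2 `CCOC(=O)C1=C(N/C=N/c2nnc(S(N)(=O)=O)s2)Nc2[nH]nc(C)c2C1c1ccc(N(C)C)cc1` — 38100 nM

Both numbers come from a functional assay on HepG2 cells (Homo sapiens) for inhibition, read by MTT assay, with a stated time of 48 h; on this read-out higher numbers stand for weaker inhibition and lower numbers for stronger inhibition. On these two numbers compound 1 stands highest, and its nearest neighbour is compound 2, reached by a 1.2-fold lower number from compound 1 to compound 2 (0.09 log units; within the scatter). Compound 3 `CCOC(=O)C1=C(N/C=N/c2ccccn2)Nc2[nH]nc(C)c2C1c1ccc(N(C)C)cc1` differs from compound 1 by a group of 8 heavy atoms (6 carbon, 2 nitrogen; one six-membered aromatic ring with 1 hetero atom) in place of a group of 9 heavy atoms (5 carbon, 2 nitrogen, 2 oxygen; no ring), on an amine nitrogen. Within the data shown here, the only measured step that bears on this position is the one from compound 1 to compound 2, which exchanged the same leaving group for a different ring-bearing group on the same amine nitrogen and gave a 1.2-fold lower number from compound 1 to compound 2 (0.09 log units; within the scatter); nothing else at this position has been measured. Since that one comparable exchange stayed within the scatter, the step to compound 3 in this assay is expected to be a 1.1-fold lower number from compound 1 to compound 3 (0.04 log units; within the scatter), that is, none beyond the scatter. Compound 3 is accordingly estimated at 42000 nM in this assay, with a range from 15000 nM to 120000 nM.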

Compound 3, half-maximal inhibitory concentration: 26200 nM
The estimate for compound 3 lay 1.6-fold (0.20 log units) above the measured number; low and high end bracket the measured number.
By their numbers in this assay, from the lowest: compounds 3, 2 and 1 (each within the scatter of the next).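

In this assay, pyridin-2-yl on the amine nitrogen gives a 1.8-fold lower number from compound 1 to compound 3 (0.25 log units; within the scatter) against the open-chain group of 9 heavy atoms, and in place of 5-sulfamoyl-1,3,4-thiadiazol-2-yl on a double-bonded nitrogen it gives a 1.5-fold lower number from compound 2 to compound 3 (0.16 log units; within the scatter) in the same assay. Among these compounds, the position now holds an open chain, a five-membered aromatic ring and a six-membered aromatic ring, and no step among compounds 1, 2 and 3 leaves the scatter, so the sulfamoyl-bearing ring of compound 2 shows no separate standing against the plain pyridine ring of compound 3. Nothing accompanying these numbers speaks to what lies behind them.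

Still open, going by these compounds, is whether any group on this nitrogen moves the number beyond the scatter. A plain phenyl ring, or a pyridine ring carrying a carboxylic acid or an amine, would test this.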